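Swapping a thiazole for a pyridine on a sulfonamide nitrogen

The source may report more compounds than this note shows. Statements on the series, on what has been measured and on what is new or still open speak of the compounds shown alone.

Two pairs of compounds share one structural change at one spot. Compound 1 `O=c1[nH]cnc2c1c(-c1ccccc1)cn2-c1ccc(S(=O)(=O)Nc2nccs2)cc1` and compound 2 `O=c1[nH]cnc2c1c(-c1ccccc1)cn2-c1ccc(S(=O)(=O)Nc2ccccn2)cc1` differ only in that (pyridin-2-yl in place of 1,3-thiazol-2-yl on a sulfonamide nitrogen). In a functional assay on HepG2 cells (Homo sapiens) for inhibition, read by sulforhodamine B assay, with a stated time of 24 h (on this read-out higher numbers stand for weaker inhibition and lower numbers for stronger inhibition), compound 1 gives 5300 nM, and compound 2 gives 4670 nM; the step of a 1.1-fold lower number from compound 1 to compound 2 (0.05 log units; within the scatter) is within the scatter, so the two compounds read alike.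

Compound 3 `CC(=O)Nc1c(C#N)c(-c2ccccc2)cn1-c1ccc(S(=O)(=O)Nc2nccs2)cc1` carries a different core; the difference between the core of compound 3 and the core of compound 1 is not broken down here. In this assay compound 3 gives 4020 nM, within the scatter of both compound 1 and compound 2.

Compound 4 `CC(=O)Nc1c(C#N)c(-c2ccccc2)cn1-c1ccc(S(=O)(=O)Nc2ccccn2)cc1` is not yet measured. It stands to compound 3 as compound 2 stands to compound 1: pyridin-2-yl in place of 1,3-thiazol-2-yl on a sulfonamide nitrogen. The place is the same in both pairs, a sulfonamide nitrogen whose other neighbour is the sulfonyl sulfur. Because the earlier step of a 1.1-fold lower number from compound 1 to compound 2 (0.05 log units; within the scatter) stayed within the scatter, a matching small step is expected, a 1.1-fold lower number from compound 3 to compound 4 (0.04 log units; within the scatter). Compound 4 is therefore estimated at 3700 nM, with a likely range from 1800 nM to 7500 nM.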

Compound 4, half-maximal inhibitory concentration: 3490 nM
Beside the measured number, compound 4's estimate is 1.1-fold (0.03 log units) above it; low and high end bracket the measured number.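

On the second core, the swap gives a 1.2-fold lower number from compound 3 to compound 4 (0.06 log units; within the scatter) in this assay, so here too the two compounds read alike. Set side by side, the two steps do not differ, and the change behaves the same way on both cores: the same change on two cores in this assay, a 1.1-fold lower number (0.05 log units; within the scatter) from compound 1 to compound 2 and a 1.2-fold lower number (0.06 log units; within the scatter) from compound 3 to compound 4, 1.0-fold (0.01 log units) apart, within the scatter of two such steps This shows only that pyridin-2-yl and 1,3-thiazol-2-yl on the sulfonamide nitrogen read alike on these two cores in this one assay; as neither step rises above the scatter, it does not show that the two cores would also match for a change that moves the number clearly.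

From the compounds shown here alone, only these two aromatic rings stand on the sulfonamide nitrogen here, so it stays open whether a quite different group there, such as a methyl group, a longer alkyl chain or a chain ending in a carboxylic acid, would shift the number beyond the scatter. Going by these compounds, it also stays open whether the same swap would read alike on a third core.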